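The compounds below may be only part of what the source reports. "The series", "measured", "known", "first", "only" and "open" are said of these compounds alone.

In an ADME assay on liver for metabolic stability, with Liver microsome (Rattus norvegicus) as the target, read by LC-MS, using microsomes, with a stated time of 5 h (a lower number here means slower removal, a higher number faster removal of the compound), three compounds have been measured so far. Compound 1 `O[C@H](c1ccccn1)[C@]1(c2cc(C(F)(F)F)ccn2)C[C@@H](O)C1` gives 50 mL/min/kg. Compound 2 `O[C@@]1(c2ccccn2)CC[C@@H](c2ccc(C(F)(F)F)cc2)C1` gives 2520 mL/min/kg. Compound 3 `C[C@]1(O)C[C@@](c2ccc(OC(F)(F)F)cc2)([C@@H](O)c2ccccn2)C1` gives 100 mL/min/kg, the second highest of the three numbers; its number and that of compound 1 lie within the usual scatter of this assay, so nothing separates the two, while compound 2 stands far higher, beyond the scatter. Compound 4 `C[C@]1(O)C[C@](c2ccc(OC(F)(F)F)cc2)([C@H](O)c2ccccn2)C1` has not yet been measured. It differs from compound 3 only in configuration: the two compounds have the same atoms and bonds and differ only in configuration as drawn: 2 of 3 stereo elements differ; a stereocentre at a saturated ring carbon is drawn s in compound 3 and r in compound 4; a stereocentre at a saturated chain carbon is drawn R in compound 3 and S in compound 4. Going by the values given here, no pair of measured compounds shows what such a change in configuration does in this assay, so the size of the coming step is uncertain. A change of configuration alone is expected to give a step of no change at the digits printed from compound 3 to compound 4 (within the scatter), which is not expected to reach beyond the scatter in either direction. Compound 4 is therefore expected to give 100 mL/min/kg, with a range from 40 mL/min/kg to 300 mL/min/kg.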

Compound 4, clearance: 100 mL/min/kg
For compound 4 middle estimate and measured number coincide at the digits printed, within the range that was stated.
By their numbers in this assay, from the lowest: compounds 1, 3 and 4 (each within the scatter of the next); then compound 2.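

In this assay, going by these compounds alone, the result is no change at the digits printed from compound 3 to compound 4 (within the scatter), the first step that can be read for a single kind of change, since no earlier pair differed in one place only. The comparison isolates stereochemistry because nothing else varies within the pair: the fact that compounds 3 and 4 differ only in the configuration as drawn. For this pair, changing the drawn configuration at the saturated ring carbon and the saturated chain carbon together leaves no mark on the rate of removal that stands clear of the scatter.

The pair leaves open what each of these two stereocentres does alone, since both change at once, and what a change at the third stereo element would do. It also leaves open whether configuration would matter as little in compounds carrying an amine or a carboxylic acid in place of the trifluoromethoxy group.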